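The source may report more compounds than this note shows. Statements on the series, on what has been measured and on what is new or still open speak of the compounds shown alone.

Three compounds share one core and differ only in the group on an amine nitrogen in a ring. Compound 1 `COc1ccc(N2CCN(Cc3csc(N)c3C(=O)c3ccc(Cl)cc3)CC2)cc1` gives 0% in an assay on CHO cells for displacement of a labelled ligand from adenosine receptor A3 (Homo sapiens), read by scintillation counting, with a stated time of 120 min, tested at 10 uM; on this read-out lower numbers stand for less inhibition and higher numbers for more inhibition at the one concentration tested (going by the name of the read-out); compound 2 `Nc1scc(CN2CCN(c3cccc(F)c3)CC2)c1C(=O)c1ccc(Cl)cc1` gives 4%; compound 3 `Nc1scc(CN2CCN(c3cc(F)cc(F)c3)CC2)c1C(=O)c1ccc(Cl)cc1` gives 2%. On these numbers compound 3 stands second highest of the three, nearest to compound 1 and furthest from compound 2, with both gaps inside the scatter. The steps of a number 4 percentage points higher from compound 1 to compound 2 (within the scatter), a number 2 percentage points higher from compound 1 to compound 3 (within the scatter) and a number 2 percentage points lower from compound 2 to compound 3 (within the scatter) all stay within the scatter. Compound 4 `Nc1scc(CN2CCN(CCCc3ccc(Cl)cc3)CC2)c1C(=O)c1ccc(Cl)cc1` carries 3-(4-chlorophenyl)propyl in place of 3,5-difluorophenyl on an amine nitrogen in a ring. Every measured step exchanges the group on that same nitrogen without moving the number beyond the scatter, so the step of a number 1 percentage points higher from compound 3 to compound 4 (within the scatter) is expected to stay within it. Compound 4 is therefore estimated at 3%, between 0% and 12%.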

Compound 4, a percentage reported as inhibition, at one concentration (the size of the read-out at that concentration, not a potency): 0%
Compound 4: middle estimate off by 3 percentage points, on the high side; the range from low to high includes it.
By their numbers in this assay, from the lowest: compounds 1, 4, 3 and 2 (each within the scatter of the next).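

Until now only phenyl groups carrying a methoxy or fluoro substituent had stood on this amine nitrogen, and compound 4 shows that 3-(4-chlorophenyl)propyl, which brings in a chain, also leaves this assay flat: the steps read a number 2 percentage points lower from compound 3 to compound 4 (within the scatter) and a number 4 percentage points lower from compound 2 to compound 4 (within the scatter) and no change at the digits printed from compound 1 to compound 4 (within the scatter) on that same nitrogen. With all four compounds within the scatter of each other, no group at this position stands out. Nothing at hand explains this flat result. Open, on these data alone, is whether a longer chain ending in an amine or a carboxylic acid on this nitrogen would move the number beyond the scatter. Changes elsewhere on the shared core, such as replacing the 4-chlorophenyl ketone, also remain open.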